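Adding a Methoxy Group to Compound 3

The compounds below may be only part of what the source reports. "The series", "measured", "known", "first", "only" and "open" are said of these compounds alone.

Four compounds share one core. Compound 1 `COc1ccc(-c2cc(C(=O)/C=C/c3ccccc3)nc3cc(-c4ccccc4)nn23)cc1OC` and compound 2 `COc1cc(-c2cc(C(=O)/C=C/c3ccccc3)nc3cc(-c4ccccc4)nn23)cc(OC)c1OC` differ by methoxy in place of hydrogen on an aromatic carbon. Compound 3 `COc1ccc(C(=O)/C=C/c2cc(-c3ccc(OC)c(OC)c3)n3nc(-c4ccccc4)cc3n2)cc1` differs from compound 1 by 2-((4-methoxyphenyl)carbonyl)ethenyl in place of (2-phenylethenyl)carbonyl on an aromatic carbon. Compound 4 `COc1ccc(C(=O)/C=C/c2cc(-c3ccc(OC)c(OC)c3)n3nc(-c4ccccc4)cc3n2)cc1OC` is not yet measured and differs from compound 3 by methoxy in place of hydrogen on an aromatic carbon. This is the same kind of change as that from compound 1 to compound 2, though not the same: in compound 2 the entering group is also meta to a methoxy group, which is not so in compound 4.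

In a functional assay on DU-145 cells (Homo sapiens) for antiproliferative activity, read by MTT assay, with a stated time of 24 h (on this read-out lower numbers stand for stronger inhibition and higher numbers for weaker inhibition), compound 1 gives 15600 nM, compound 2 gives 16300 nM and compound 3 gives 14600 nM. The added methoxy made a 1.0-fold higher number from compound 1 to compound 2 (0.02 log units; within the scatter), and the change of core made a 1.1-fold lower number from compound 1 to compound 3 (0.03 log units; within the scatter). All three values lie within the scatter of one another.

Compound 4 is expected to give 15000 nM, with a range from 7500 nM to 30000 nM, because a 1.0-fold higher number from compound 1 to compound 2 (0.02 log units; within the scatter) lay within the scatter. The expected step is a 1.0-fold higher number from compound 3 to compound 4 (0.01 log units; within the scatter). The measured value follows.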

Compound 4, half-maximal inhibitory concentration: 7200 nM
The estimate for compound 4 lay 2.1-fold (0.32 log units) above the measured number; the whole stated range lies above it.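

In this assay, methoxy in place of hydrogen gave a 2.0-fold lower number from compound 3 to compound 4 (0.31 log units; beyond the scatter), a modest step, while the same kind of change on the core of compound 1 gave a 1.0-fold higher number from compound 1 to compound 2 (0.02 log units; within the scatter). Set side by side, the two steps cannot be told apart: the same change on two cores in this assay, a 1.0-fold higher number (0.02 log units; within the scatter) from compound 1 to compound 2 and a 2.0-fold lower number (0.31 log units; beyond the scatter) from compound 3 to compound 4, 2.1-fold (0.33 log units) apart, within the scatter of two such steps. Within the data shown here, the change therefore lowered the number beyond the scatter on one core only, but this shows neither that the core decides its effect nor that the effect carries over from one core to the other, since there are only two pairs and the methoxy enters a different setting in each.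

The compounds shown leave open whether a hydroxy group, an amine or a longer alkoxy chain in place of the entering methoxy on the (3,4-dimethoxyphenyl)carbonyl part would give a number like that of compound 4. They also leave open whether the step from compound 3 to compound 4 would recur on a third core.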